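The source may report more compounds than this note shows. Statements on the series, on what has been measured and on what is new or still open speak of the compounds shown alone.

In an in vitro ADME assay on microsomes from liver (Mus musculus) for pharmacokinetics (a higher number here means faster removal of the compound, a lower number slower removal), two compounds sharing one core have been measured so far. Compound 1 `COc1ccc(CN([C@@H]2CC(F)(F)CCNC2=O)S(=O)(=O)c2ccc(Cl)cc2)cn1` gives 72 mL.min-1.g-1 and holds the higher of the two numbers. Compound 2 `O=C(NC1CC1)c1ccc(CN([C@@H]2CC(F)(F)CCNC2=O)S(=O)(=O)c2ccc(Cl)cc2)cc1` gives 2.2 mL.min-1.g-1 in this assay and lies lower by a gap well beyond the scatter of repeat measurements. Going by the values given here, no pair of measured compounds differs in a single place, so the data offer no direct guide to the size of a single change.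

Compound 3 `COc1ccc(CN([C@@H]2CC(F)(F)CCNC2=O)S(=O)(=O)c2ccc(Cl)cc2)c(F)c1` has not yet been measured and departs from compound 1 in one place 2-fluoro-4-methoxyphenyl in place of 6-methoxypyridin-3-yl on a saturated chain carbon bound to a sulfonamide nitrogen with 2-fluoro-4-methoxyphenyl in place of 6-methoxypyridin-3-yl on a saturated chain carbon bound to a sulfonamide nitrogen. Both groups are methoxy-bearing six-membered aromatic rings, and compound 1 at 72 mL.min-1.g-1 is the natural reference, so no change beyond the scatter is expected in this assay for this swap. The estimated step of a 1.2-fold higher number from compound 1 to compound 3 (0.07 log units; within the scatter) is expected to stay within that scatter. For compound 3 the expected value is 85 mL.min-1.g-1 with an estimated range from 35 mL.min-1.g-1 to 190 mL.min-1.g-1 across repeat measurements.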

Compound 3, intrinsic clearance in microsomes: 105 mL.min-1.g-1
Compound 3: middle estimate off by 1.2-fold (0.09 log units), on the low side; the measured number falls inside the stated range.
By their numbers in this assay, from the lowest: compound 2; then compounds 1 and 3 (each within the scatter of the next).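

In this assay, going by these compounds alone, putting 2-fluoro-4-methoxyphenyl in place of 6-methoxypyridin-3-yl on a saturated chain carbon bound to a sulfonamide nitrogen gives a 1.5-fold higher number from compound 1 to compound 3 (0.16 log units; within the scatter), the first step in this set that can be read for a change in a single place. It shows that, at this position, a six-membered aromatic ring of carbon only bearing fluorine and methoxy can stand in for the methoxy-bearing ring with one hetero atom without the number leaving the scatter, so this exchange alone does not open a gap of the size that separates compound 2 from the others. Nothing measured here bears on why the change leaves the number within the scatter.

Within the data shown here, the single step changes the ring atom and the fluorine together, so the share of each stays unknown, and the link between the cyclopropyl amide of compound 2 and its number remains unread, since compound 2 differs from the others in more than one place. Also open, from the compounds shown here alone, is how the number would respond at this position to a ring carrying a carboxylic acid or an amine instead of the methoxy group.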